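This account rests on a few compounds, and the source may have more. Where it says the series, first, only, none or still open, it means among the compounds named here.

Compound 1 `CC(C)n1ncc2c(C(=O)Nc3cccc(C(N)=O)c3)cc(-c3cccs3)nc21`: 25000 nM
Compound 2 `CC(C)n1ncc2c(C(=O)Nc3c(F)cccc3F)cc(-c3cccs3)nc21`: > 200000 nM (a limit)
Compound 3 `CC(C)n1ncc2c(C(=O)Nc3ccccn3)cc(-c3ccsc3)nc21`: 25000 nM

In an ADME assay on LLC-MK2 cells (Macaca mulatta) for cytotoxicity, read by spectrophotometry and crystal violet staining, with a stated time of 4 days (a higher number here means that more compound is tolerated, a lower number that less compound is tolerated), compound 2 stands at the limit of > 200000 nM in this assay, at which 1 of the 3 values shown sits, so its reading is a limit and not a number. Compound 4 `CC(C)n1ncc2c(C(=O)Nc3cccc(F)c3)cc(-c3cccs3)nc21` differs from compound 2 at one place: 3-fluorophenyl in place of 2,6-difluorophenyl on an amide-type nitrogen. Going by the values given here, the only measured step at this amide-type nitrogen is an at least 8.0-fold higher number from compound 1 to compound 2 (0.90 log units; beyond the scatter), and it ends at that limit. Among the compounds with values here, that step is the sole guide, and the 2,6-difluorophenyl group involved in it leaves in compound 4. A fall towards compound 1, which gives 25000 nM, is therefore expected, but probably not all the way. The expected step is an at least 2.5-fold lower number from compound 2 to compound 4 (0.39 log units; beyond the scatter), with less compound tolerated. For compound 4 the estimated value is 80000 nM, with an expected range from 25000 nM to 200000 nM.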

Compound 4, half-maximal cytotoxic concentration: > 200000 nM
Compound 4 was reported as a limit; the forecaster's own chance of this, stated with the estimate: 30%; middle value at least 2.5-fold (0.39 log units) away from the limit.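

In this assay compound 4 gives > 200000 nM, which is a limit and not a number. The step between compound 2 and compound 4 cannot be read, and the reading at this limit is now shared: the limit of > 200000 nM in this assay, at which 2 of the 4 values shown sit. At the amide-type nitrogen, the reading at the limit therefore does not depend on 2,6-difluorophenyl, and fluoro in place of carbamoyl on an aromatic carbon gives an at least 8.0-fold higher number from compound 1 to compound 4 (0.90 log units; beyond the scatter). Still open, as far as these compounds go, is how far compound 2 and compound 4 differ beyond the limit, and whether a carboxylic acid or an amine in place of the fluoro group would keep the reading there.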